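Aryl variation on the shared core: compound 3 to compound 4

The source may report more compounds than this note shows. Statements on the series, on what has been measured and on what is new or still open speak of the compounds shown alone.

Compound 1 `COc1cc(-c2ccc3ncn(-c4cc(OC)c(OC)c(OC)c4)c3c2)cc(OC)c1OC` reaches only a limit in a functional assay on MCF7 cells (Homo sapiens) for antiproliferative activity, read by MTT assay, with a stated time of 72 h (a higher number here means a weaker inhibitor, a lower number a stronger inhibitor), giving > 10000 nM, which is the limit of the assay (the limit of > 10000 nM in this assay, at which 1 of the 3 values shown sits). Compound 2 `COc1cc(-n2cnc3ccc(-c4ccc(Cl)cc4)cc32)cc(OC)c1OC` gives a number in this assay of 1320 nM. Compound 3 `COc1cc(-n2cnc3ccc(-c4cccc(C)c4C)cc32)cc(OC)c1OC` gives 2150 nM in this assay; of the two numbers shown this is where compound 3 stands, and the step of a 1.6-fold higher number from compound 2 to compound 3 (0.21 log units; within the scatter) lies within the scatter, so the two stand together.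

Compound 4 `COc1cc(-n2cnc3ccc(-c4ccc(Cl)cc4Cl)cc32)cc(OC)c1OC` differs from compound 3 in one place: 2,4-dichlorophenyl in place of 2,3-dimethylphenyl on an aromatic carbon. Within the data shown here, the only measured step that bears on this position is a 1.6-fold higher number from compound 2 to compound 3 (0.21 log units; within the scatter), which exchanged one substituted phenyl for another and stayed within the scatter. A further exchange of the same kind is therefore expected to move the number little, with no direction beyond the scatter; the expected step is a 1.3-fold lower number from compound 3 to compound 4 (0.13 log units; within the scatter). Compound 4 is estimated at 1600 nM in this assay, with a range from 500 nM to 5000 nM.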

Compound 4, half-maximal inhibitory concentration: 5420 nM
Estimate against measurement, compound 4: 3.4-fold (0.53 log units) below, outside the stated range (above it).
By their numbers in this assay, from the lowest: compounds 2 and 3 (each within the scatter of the next); then compound 4. At a limit, above all of these: compound 1.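

In this assay, chloro in place of hydrogen on an aromatic carbon of the phenyl gives a 4.1-fold higher number from compound 2 to compound 4 (0.61 log units; beyond the scatter), a modest change but the first at this position to lie beyond the scatter. The exchange of 2,3-dimethylphenyl for 2,4-dichlorophenyl gives a 2.5-fold higher number from compound 3 to compound 4 (0.40 log units; beyond the scatter), also modest and beyond the scatter, whereas the earlier exchange gave only a 1.6-fold higher number from compound 2 to compound 3 (0.21 log units; within the scatter). The position therefore responds to the choice of substituted phenyl, but nothing at hand accounts for these steps.

Open, on these data alone, is whether the higher number belongs to the added chloro alone or to the 2,4-dichlorophenyl pattern as a whole. Also open, as far as these compounds go, is how a phenyl carrying an amine or a carboxylic acid would stand against compound 2 at 1320 nM.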